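The source may report more compounds than this note shows. Statements on the series, on what has been measured and on what is new or still open speak of the compounds shown alone.

Two compounds in this series have been run through an ADME assay on HepG2 cells (Homo sapiens) for cytotoxicity, read by CellTiter-Glo and resazurin assay, with a stated time of 72 h (a higher number here means that more compound is needed for the effect, a lower number that less compound is needed), both built on the same core. Compound 1 `CCOC(=O)CCCCCOc1cccc(CN(C(=O)c2ccc(-c3ccoc3)cc2)C(C)C)c1` carries a furan-3-yl group, and in this assay compound 1 gives only a limit, > 26000 nM, which is the limit of > 26000 nM in this assay, at which 1 of the 2 values shown sits. Compound 2 `CCOC(=O)CCCCCOc1cccc(CN(C(=O)c2ccc(-c3cccc(OCC)c3)cc2)C(C)C)c1` carries a 3-ethoxyphenyl group in its place, and in this assay compound 2 likewise gives only a limit, > 22300 nM, which is the limit of > 22300 nM in this assay, at which 1 of the 2 values shown sits. Going by the values given here, compound 2 therefore stands where the one other value stands: at a limit of the assay rather than at a number, and the step that the two limits leave unreadable from compound 1 to compound 2 cannot be read, since both of its ends are limits.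

Compound 3 `CCOC(=O)CCCCCOc1cccc(CN(C(=O)c2ccc(-c3cc(F)cc(OC)c3)cc2)C(C)C)c1` differs from compound 2 by 3-fluoro-5-methoxyphenyl in place of 3-ethoxyphenyl on an aromatic carbon. Among the compounds with values here, the only measured step that bears on this change is the one from compound 1 to compound 2, and its size is not readable, so no step beyond the scatter can be predicted in either direction; the expectation is simply that compound 3 stays where compound 2 stands. Compound 3 is expected to give about 25000 nM, within the range 10000 nM to 80000 nM. This corresponds to an expected step that the limit leaves unreadable from compound 2 to compound 3.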

Compound 3, half-maximal effective concentration: > 26000 nM
Compound 3 was reported as a limit; the forecaster's own chance of this, stated with the estimate: 75%; middle value at least 1.0-fold (0.01 log units) from the limit.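

In this assay compound 3 gives only a limit (> 26000 nM). Going by these compounds alone, with compound 1 and compound 2 also at limits, no step among compound 1, compound 2 and compound 3 can be read. What the compounds shown leave open is whether in this assay the furan-3-yl, 3-ethoxyphenyl and 3-fluoro-5-methoxyphenyl compounds differ at all, as none of the three has a number there.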